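The source may hold more compounds than are shown below. What is called first, only, known or untested is meant among the compounds shown, and "the series" means these compounds.

Working notes on the series, all read in a functional assay on OVCAR-8 cells (Homo sapiens) for inhibition, read by sulforhodamine B assay, with a stated time of 48 h, tested at 10 uM; a lower number here means less inhibition, a higher number more inhibition at the concentration tested (going by the name of the read-out).

Compound 1 `O=Cc1ccc(-c2cn3ccnc3c(-c3ccc4ncn(C5CCCCC5)c4c3)n2)cc1` gives 44% in this assay. Compound 2 `O=Cc1ccc(-c2cn3ccnc3c(-c3ccc4ncn(Cc5ccccc5)c4c3)n2)cc1` is related to it by benzyl in place of cyclohexyl on an aromatic nitrogen; in this assay compound 2 gives 44%. Within the data shown here, the step of no change at the digits printed from compound 1 to compound 2 (within the scatter) is the only measured instance of this change so far.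

Compound 3 `c1cn2cc(-c3ccc4c(c3)ncn4C3CCCCC3)nc(-c3ccc4ncn(C5CCCCC5)c4c3)c2n1` rests on a different core; the difference between the core of compound 1 and the core of compound 3 is not broken down here. In this assay compound 3 gives 42.6%, a number that lies within the scatter of both compound 1 and compound 2, so nothing separates the three on the numbers alone.

Compound 4 `c1ccc(Cn2cnc3ccc(-c4nc(-c5ccc6c(c5)ncn6C5CCCCC5)cn5ccnc45)cc32)cc1` is not yet measured. It differs from compound 3 by benzyl in place of cyclohexyl on an aromatic nitrogen. The place is described in exactly the same words as for the pair of compound 1 and compound 2, so this is the same change made a second time, now on the core of compound 3. Among the measured compounds shown here, the step from compound 3 to compound 4 is expected to be a number 0.4 percentage points higher from compound 3 to compound 4 (within the scatter) because the one measured instance of the change came out as no change at the digits printed from compound 1 to compound 2 (within the scatter). Compound 4 is therefore estimated at 43%, with four of five repeat measurements expected between 30% and 56%. For the measured compounds named here, this rests on the value of compound 3, 42.6%, as the starting point and on the single prior instance; a second core may not repeat the behaviour of the first, which widens the range.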

Compound 4, a percentage reported as inhibition, at one concentration (the size of the read-out at that concentration, not a potency): 97.6%
For compound 4 the middle estimate is 54.6 percentage points below the measured one; the whole stated range lies below it.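

Benzyl in place of cyclohexyl on an aromatic nitrogen, read in this assay, gives a number 55 percentage points higher from compound 3 to compound 4 (beyond the scatter). Set beside the earlier instance, this shows that the size of the step does not carry from one core to the other in this series, so the result on the core of compound 1 is no guide to the result on the core of compound 3: the same change on two cores in this assay, no change at the digits printed (within the scatter) from compound 1 to compound 2 and a number 55 percentage points higher (beyond the scatter) from compound 3 to compound 4, 55 percentage points apart, beyond the scatter of two such steps

What this does not show is which difference between the two cores goes with the large step, or why it appears on one core and not on the other; two instances establish only that the outcome differs, and each read-out is a percentage at one concentration, not a potency.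

The compounds shown leave open whether the large step belongs to benzyl itself or would also appear with other groups on that aromatic nitrogen, such as a longer alkyl chain, a chain ending in an amine or one ending in a carboxylic acid. Among these compounds, they also leave open whether the cyclohexyl that compound 4 retains is needed for the high reading, since no compound here has that group replaced while the benzyl stays in place.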